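Compound 3 to compound 4: trifluoromethyl for chloro

The source may report more compounds than this note shows. Statements on the series, on what has been measured and on what is new or still open speak of the compounds shown alone.

Measured so far in a functional assay on Caco-2 cells (Homo sapiens) for antiproliferative activity, with a stated time of 48 h; on this read-out higher numbers stand for weaker inhibition and lower numbers for stronger inhibition:
- compound 1 `CCN(CC)c1ccc(-c2cccc(OC)c2)nn1` gives > 25000 nM (a limit)
- compound 2 `COC(=O)c1cccc(-c2ccc(-n3cccc3)nn2)c1` gives 50000 nM (a number)
- compound 3 `CCN(CC)c1ccc(-c2cccc(Cl)c2)nn1` gives > 25000 nM (a limit)

Compound 3 gives > 25000 nM as a limit only. It sits at the limit of > 25000 nM in this assay, at which 2 of the 3 values shown sit, and nothing finer can be read. Going to compound 4 `CCN(CC)c1ccc(-c2cccc(C(F)(F)F)c2)nn1` puts trifluoromethyl in place of chloro on an aromatic carbon, with trifluoromethyl in place of chloro on an aromatic carbon as the counted change. For the measured compounds named here, the one measured step that bears on this is a step that the two limits leave unreadable from compound 1 to compound 3 and gives no size to carry over. No step beyond the scatter is therefore expected in this assay in either direction. The expected move is a step that the limit leaves unreadable from compound 3 to compound 4 on that reading. Compound 4 is estimated at 35000 nM with an expected range of 15000 nM to 80000 nM and may return only a limit.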

Compound 4, half-maximal inhibitory concentration: > 25000 nM
Compound 4: no number, only a limit; the forecaster's own chance of this, stated with the estimate: 60%; the middle value does not contradict the limit.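

Compound 4 gives > 25000 nM in this assay, a limit and not a number. For the compounds shown here, no step to it from compound 1 or compound 3 can be read. The compounds shown leave open whether methoxy, chloro or trifluoromethyl on the aromatic carbon differ at all, with the values resting at one point: the limit of > 25000 nM in this assay, at which 3 of the 4 values shown sit.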